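The source may report more compounds than this note shows. Statements on the series, on what has been measured and on what is new or still open speak of the compounds shown alone.

In a physicochemical assay for solubility, read by HPLC, in phosphate buffer, measured as kinetic solubility, with a stated time of 1 h, at pH 7.4, tested at 250 uM (a higher number here means a more soluble compound, a lower number a less soluble compound), compound 1, `CC(C)CNC(=O)n1c(=O)oc2cc(C3CCCCN3C)ccc21`, gives 190000 nM, and compound 2, `CN1CCC(c2ccc3c(c2)oc(=O)n3C(=O)NCCOCc2ccccc2)CC1`, gives 73000 nM. Compound 3, `CN1CCN(c2ccc3c(c2)oc(=O)n3C(=O)NCCCCc2ccccc2)CC1=O`, returns only a limit of the assay, reported as < 1000 nM; this is the limit of < 1000 nM in this assay, at which 1 of the 3 values shown sits. Compound 4, `CCN1CCN(c2ccc3c(c2)oc(=O)n3C(=O)NCCCCc2ccccc2)CC1`, has not yet been measured; it differs from compound 3 by 4-ethylpiperazin-1-yl in place of 4-methyl-3-oxopiperazin-1-yl on an aromatic carbon. For the measured compounds named here, no measured pair of compounds shares this change, so the size of the step can only be judged from the three values at hand, of which compound 1 and compound 2 show where the readily soluble members of the set lie. Compound 4 is expected to give about 40000 nM, with a range of 5000 nM to 150000 nM. The step expected here, an at least 40-fold higher number from compound 3 to compound 4 (1.60 log units; beyond the scatter), would carry the reading toward the values of compound 1 and compound 2.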

Compound 4, solubility: < 1000 nM
Compound 4 gave a limit, no number; the forecaster's own chance of this, stated with the estimate: 15%; at least 40-fold (1.60 log units) between middle value and limit.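

In this assay, for the compounds shown here, compound 3 and compound 4 both return only a limit of the assay, and no step between them can be read: the limit of < 1000 nM in this assay, at which 2 of the 4 values shown sit. The compounds shown leave open whether 4-ethylpiperazin-1-yl in place of 4-methyl-3-oxopiperazin-1-yl changes the reading at all.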